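Ethyl on the ring nitrogen of compound 1

This account rests on a few compounds, and the source may have more. Where it says the series, first, only, none or still open, it means among the compounds named here.

Compound 1 `O=C(NCc1ccccc1)c1nc(Cc2ccccc2C(F)(F)F)[nH]c(=O)c1O`: > 100000 nM
Compound 2 `Cn1c(Cc2ccccc2C(F)(F)F)nc(C(=O)NCC2CCCCC2)c(O)c1=O`: > 100000 nM

Both entries come from an ADME assay on HepG2 cells (Homo sapiens) for cytotoxicity, in the presence of a further agent that is not named here (on this read-out higher numbers stand for weaker inhibition and lower numbers for stronger inhibition), and each is a limit of the assay, not a number. Compound 1 therefore stands at > 100000 nM, with no exact value known. Compound 3 `CCn1c(Cc2ccccc2C(F)(F)F)nc(C(=O)NCc2ccccc2)c(O)c1=O` has ethyl in place of hydrogen on an aromatic nitrogen of compound 1: ethyl in place of hydrogen on an aromatic nitrogen. Going by the values given here, no measured step covers this change, so the only guide is the limit of > 100000 nM in this assay, at which 2 of the 2 values shown sit. The expected step, a number no higher from compound 1 to compound 3 (the limit leaves the size open), has no direction beyond the scatter in this assay. For compound 3 the estimated value is 100000 nM, with an expected range of 40000 nM to 200000 nM.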

Compound 3, half-maximal inhibitory concentration: > 100000 nM
Compound 3 was reported as a limit; the forecaster's own chance of this, stated with the estimate: 80%; the middle value lies on the limit itself.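

In this assay compound 3 gives > 100000 nM, a limit and not a number. Going by these compounds alone, compound 1 also stands at a limit, and no step from compound 1 to compound 3 can be read. The compounds shown leave open whether ethyl in place of hydrogen on the aromatic nitrogen changes the read-out at all.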